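The source may hold more compounds than are shown below. What is called first, only, known or untested is meant among the compounds shown, and "the series" means these compounds.

Compound 3 `CC1CC(C)CN(CC(=O)N2N=C(c3cc4ccccc4oc3=O)CC2c2ccccc2)C1` is one of four close relatives that share a common core and differ only in the amine attached to the chain carbon next to the carbonyl. In a functional assay on HepG2 cells (Homo sapiens) for cytotoxicity, read by MTT assay, with a stated time of 48 h (on this read-out higher numbers stand for weaker inhibition and lower numbers for stronger inhibition), compound 3 gives "not active" (no number reported), and no concentration was given for it, so it stands outside the numbered series. Its two measured neighbours give a sense of where the series lies: compound 1 `CCNCC(=O)N1N=C(c2cc3ccccc3oc2=O)CC1c1ccccc1` gives 30600 nM in this assay, and compound 2 `O=C(CNC1CCCCC1)N1N=C(c2cc3ccccc3oc2=O)CC1c1ccccc1` gives 34400 nM. Among the measured compounds shown here, the one step that can be read between measured compounds, a 1.1-fold higher number from compound 1 to compound 2 (0.05 log units; within the scatter), shows that exchanging an ethyl for a cyclohexyl on the amine nitrogen left the read-out where it was.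

Compound 4 `NC(=O)C1CCN(CC(=O)N2N=C(c3cc4ccccc4oc3=O)CC2c2ccccc2)CC1` arises from compound 3 by 4-carbamoylpiperidin-1-yl in place of 3,5-dimethylpiperidin-1-yl on a saturated chain carbon bound to a carbonyl carbon. For the measured compounds named here, no measured step bears directly on this exchange, and compound 3 itself carries no number from which a step could be read, so the expectation rests only on the level at which compounds 1 and 2 sit and on the absence of any activity for compound 3. Compound 4 is therefore expected to remain weak in this assay, with an estimated value of 40000 nM, in a range from 15000 nM to 110000 nM, and a real chance that it too is reported only as not active.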

Compound 4, half-maximal inhibitory concentration: 19300 nM
Beside the measured number, compound 4's estimate is 2.1-fold (0.32 log units) above it; low and high end bracket the measured number.
By their numbers in this assay, from the lowest: compounds 4, 1 and 2 (each within the scatter of the next).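

Compound 4 shows that a six-membered non-aromatic ring with 1 hetero atom, on a saturated chain carbon bound to a carbonyl carbon, can give a numbered result in this assay, which compound 3, with the same kind of ring, did not. With a 1.8-fold lower number from compound 2 to compound 4 (0.25 log units; within the scatter) and a 1.6-fold lower number from compound 1 to compound 4 (0.20 log units; within the scatter), both within the scatter, 4-carbamoylpiperidin-1-yl stands level with cyclohexylamino and ethylamino, so the read-out has not yet been moved by any measured exchange at this place. The step from compound 3 to compound 4 cannot be read, and nothing measured here accounts for the difference in how the two are reported.

The exchange from compound 3 to compound 4 removes the two methyl groups and adds the carbamoyl group at once, so the compounds shown do not separate the two changes, and piperidin-1-yl with neither group would be needed to tell them apart. On these data alone, it also remains open whether 4-carboxypiperidin-1-yl, morpholin-4-yl or anilino at this place would shift the read-out beyond the scatter or leave it at the level of compound 1, compound 2 and compound 4.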